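Isopropyl to 4-fluorobenzyl in compound 1

This account rests on a few compounds, and the source may have more. Where it says the series, first, only, none or still open, it means among the compounds named here.

Going by the values given here, in a functional assay on MV4-11 cells (Homo sapiens) for inhibition, read by luminescence, with a stated time of 72 h, tested at 5 uM (on this read-out higher numbers stand for more inhibition of growth at the one concentration tested and lower numbers for less inhibition of growth), compound 1 `C=CS(=O)(=O)NC/C=C/c1cc(OC)cc(O)c1C(=O)OC(C)C` gives 72.3% and holds the second highest of the three numbers so far. Above it stands compound 3 `CCN(CC)C/C=C/C(=O)NC/C=C/c1cc(OCCc2ccc(F)cc2)cc(O)c1C(=O)OC(C)C` with 84.9% although compound 3 differs from compound 1 in more than one place. Below compound 1 stands compound 2 `C=CS(=O)(=O)NC/C=C/c1cc(OC)cc(O)c1C(=O)OCc1ccc(Br)cc1` with 61%.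

Compound 4 `C=CS(=O)(=O)NC/C=C/c1cc(OC)cc(O)c1C(=O)OCc1ccc(F)cc1` has not been measured yet. The change that leads to it is 4-fluorobenzyl in place of isopropyl on an oxygen next to a carbonyl group and in short it is 4-fluorobenzyl in place of isopropyl on an oxygen next to a carbonyl group.

Among the compounds with values here, one measured step bears on this change. The swap to 4-bromobenzyl at the same place gave a number 11.3 percentage points lower from compound 1 to compound 2 (beyond the scatter) and that modest step lies beyond the scatter. Within the data shown here, a similar modest fall is therefore expected in this assay and the estimated step is a number 10.3 percentage points lower from compound 1 to compound 4 (beyond the scatter) with only that single step behind it. The estimate for compound 4 is 62% with an expected range from 50% to 74% for the coming measurement.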

Compound 4, percent growth inhibition at one concentration: 70.5%
Compound 4: the middle estimate sits 8.5 percentage points below what was measured; measured number inside the range.
By their numbers in this assay, from the lowest: compounds 2, 4 and 1 (each within the scatter of the next, the first and the last beyond it); then compound 3.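

In this assay the swap to 4-fluorobenzyl on an oxygen next to a carbonyl group gives a number 1.8 percentage points lower from compound 1 to compound 4 (within the scatter) and so, in this pair, a larger group carrying an aromatic ring does not move the number beyond the scatter. The fall seen with 4-bromobenzyl therefore does not extend to every halogen-bearing benzyl group here, yet fluoro in place of bromo on an aromatic carbon gives a number 9.5 percentage points higher from compound 2 to compound 4 (within the scatter) and so these two compounds cannot be told apart either. Nothing measured here offers a reason for these readings.

The compounds shown leave open how a plain benzyl group, with no halogen on its ring, would read at this place. They also leave open whether a longer chain ending in an amine would be accepted there.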